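This account rests on a few compounds, and the source may have more. Where it says the series, first, only, none or still open, it means among the compounds named here.

The study starts from a small aromatic core. Compound 1 `O=Cc1cc(Br)c(O)c(O)c1Br` has no number in a functional assay on HCT-116 cells (Homo sapiens) for cytotoxicity, read by MTT assay, with a stated time of 96 h; a higher number here means a weaker inhibitor, a lower number a stronger inhibitor: there compound 1 gives "not determined" (no result reported). Going by the values given here, compound 2 `OCc1cc(Br)c(O)c(O)c1Br` is the only compound with a result: in this assay compound 2 gives 21400 nM. Compound 3 `COCc1cc(O)c(O)c(Br)c1`, which carries a methoxymethyl group, likewise has no number in this assay, where compound 3 gives "not determined" (no result reported); it stands nowhere on the measured scale, and compound 1 shares that position without a value. The piece therefore follows the change from compound 3 to the not yet measured compound 4 `COCc1cc(Br)c(O)c(O)c1Br`, in which the difference is bromo in place of hydrogen on an aromatic carbon.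

Among the compounds with values here, no step between measured compounds exists, so nothing in the data shows how large a step from compound 3 to compound 4 in this assay would be, nor its direction. Compound 4 shares with compound 2 its bromo pattern and differs from it only in the group on the side chain, so compound 4 is expected to land near the value of compound 2 21400 nM, with no step beyond the scatter expected in either direction. Compound 4 is estimated at 20000 nM in this assay, within a range from 6000 nM to 65000 nM.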

Compound 4, half-maximal inhibitory concentration: 3480 nM
Compound 4: middle estimate off by 5.7-fold (0.76 log units), on the high side; measured number below the stated range.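

Going by these compounds alone, with the bromo pattern held constant, methyl in place of hydrogen on the side-chain oxygen gives, in this assay, a 6.1-fold lower number from compound 2 to compound 4 (0.79 log units; beyond the scatter), the first step that can be read. It shows that this assay responds to a small change on the side chain, since the methoxymethyl group of compound 4 and the hydroxymethyl group of compound 2 are the only difference between the two. The bromo group that enters ortho to the methoxymethyl group and ortho to a hydroxy group cannot itself be sized, as compound 3 has no number to set against compound 4, and no measurement offered here accounts for the side-chain step.

What the compounds shown leave open is how a longer ether chain such as ethoxymethyl, or an aminomethyl group, would read at this side-chain position in this assay. Also open, going by these compounds, is whether the contribution of the entering bromo group holds with side chains other than methoxymethyl, or whether a chloro group in its place would read the same.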